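Aryl Amine Swap: Ethoxyphenyl Out, Fluorophenyl In

The source may report more compounds than this note shows. Statements on the series, on what has been measured and on what is new or still open speak of the compounds shown alone.

compound 1 `Cc1ccc(NC2=CC(=O)c3nc4n(c3C2=O)[C@H]2OC[C@@H](O)[C@H]2OC4)cc1`: 3860 nM
compound 2 `CCOc1ccc(NC2=CC(=O)c3c(nc4n3[C@H]3OC[C@@H](O)[C@H]3OC4)C2=O)cc1`: 14400 nM
compound 3 `O=C1C=C(NC2CCCCC2)C(=O)c2c1nc1n2[C@H]2OC[C@@H](O)[C@H]2OC1`: > 16000 nM

In a functional assay on HeLa cells (Homo sapiens) for inhibition, read by sulforhodamine B assay (a higher number here means a weaker inhibitor, a lower number a stronger inhibitor), compound 1 gives 3860 nM and compound 2 gives 14400 nM. For compound 3 this assay reports only a limit, > 16000 nM. Compound 2 thus stands highest of the two numbers, with compound 1 below it by a gap beyond the scatter. Compound 4 `O=C1C(Nc2cccc(F)c2)=CC(=O)c2c1nc1n2[C@H]2OC[C@@H](O)[C@H]2OC1` has not yet been measured; it differs from compound 2 by 3-fluorophenyl in place of 4-ethoxyphenyl on an amine nitrogen. Going by the values given here, the one measured step, an at least 4.1-fold higher number from compound 1 to compound 3 (0.61 log units; beyond the scatter), replaced an aryl group with a saturated ring and does not bear directly on this change, since compound 4 keeps an aryl group. The two numbers of compound 1 and compound 2 show the smaller aryl group with the lower number, so a lower number is expected for compound 4, a 2.6-fold lower number from compound 2 to compound 4 (0.42 log units; beyond the scatter). Compound 4 is estimated at 5500 nM, between 2000 nM and 16000 nM.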

Compound 4, half-maximal inhibitory concentration: > 8000 nM
Compound 4: a limit, no number; the forecaster's own chance of this, stated with the estimate: 15%; middle value at least 1.4-fold (0.16 log units) from the limit.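

For compound 4, this assay reports only a limit, > 8000 nM, so the step from compound 2 to compound 4 cannot be read. The compounds shown leave open whether 3-fluorophenyl in place of 4-ethoxyphenyl gives a stronger or weaker inhibitor.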